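The source may report more compounds than this note shows. Statements on the series, on what has been measured and on what is new or still open speak of the compounds shown alone.

In an assay on isolated protein for inhibition of Leucine-rich repeat serine/threonine-protein kinase 2 variant G2019S (Homo sapiens), read by TR-FRET and LanthaScreen, with stated times of 50 min and 30 min, in the presence of a further agent that is not named here (on this read-out higher numbers stand for weaker inhibition and lower numbers for stronger inhibition), compound 1 `Cc1c(Nc2nc(N)c3c(C#N)c(N4CCC[C@H]4C)n(C)c3n2)cnn1C` gives 43 nM, the higher of the two numbers recorded. Compound 2 `Cc1c(Nc2nc(N)c3c(C#N)c(N4CCC[C@H]4C)n(C)c3n2)cnn1[C@@H]1CCOC1` gives 12 nM in this assay. That step, a 3.6-fold lower number from compound 1 to compound 2 (0.55 log units; beyond the scatter), came with oxolan-3-yl in place of methyl on an aromatic nitrogen. Compound 3 `C[C@@H]1CCCN1c1c(C#N)c2c(N)nc(Nc3cn(C)nc3C(F)(F)F)nc2n1C` differs from compound 1 elsewhere: 1-methyl-3-(trifluoromethyl)-1H-pyrazol-4-yl in place of 1,5-dimethyl-1H-pyrazol-4-yl on a nitrogen on an aromatic ring. No measured step touches this change, so neither size nor direction can be read from the numbers shown. Compound 3 is therefore expected to give about 50 nM in this assay, within a range of 15 nM to 160 nM, an expected step of a 1.2-fold higher number from compound 1 to compound 3 (0.07 log units; within the scatter) that should stay within the scatter.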

Compound 3, half-maximal inhibitory concentration: 358 nM
Beside the measured number, compound 3's estimate is 7.2-fold (0.85 log units) below it; the measured number lies above the stated range.
By their numbers in this assay, from the lowest: compound 2; then compound 1; then compound 3.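

In this assay the change on a nitrogen on an aromatic ring to 1-methyl-3-(trifluoromethyl)-1H-pyrazol-4-yl brings an 8.3-fold higher number from compound 1 to compound 3 (0.92 log units; beyond the scatter) and is the only step shown that raises the number. The group at this place therefore matters here, although both groups share the same ring type and the same counts of donors and acceptors. Nothing given here accounts for the size or direction of this step.
As far as these compounds go, it remains open whether a chlorine atom or an ethyl group in place of trifluoromethyl would raise the number as well. From the compounds shown here alone, it is also open whether the same change would raise the number with oxolan-3-yl on the aromatic nitrogen.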